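Methoxymethyl in place of vinyl on the furanylmethyl xanthine

The source may report more compounds than this note shows. Statements on the series, on what has been measured and on what is new or still open speak of the compounds shown alone.

Of the compounds shown here, three sharing one core have been measured in an assay on cell membranes for displacement of a labelled ligand from adenosine receptor A1 (Rattus norvegicus); a higher number here means a weaker inhibitor, a lower number a stronger inhibitor. Compound 1 `CCn1c(=O)c2c(nc(Cc3cccs3)n2C)n(Cc2ccco2)c1=O` gives 102 nM. Compound 2 `CCCn1c(=O)c2c(nc(Cc3ccco3)n2C)n(Cc2ccco2)c1=O` gives 132 nM. Compound 3 `C=CCn1c(=O)c2c(nc(Cc3c(F)cccc3F)n2C)n(Cc2ccco2)c1=O` gives 132 nM, which sits at the same digits as compound 2 and within the scatter of compound 1, so the three numbers cannot be told apart.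

Compound 4 `COCCn1c(=O)c2c(nc(Cc3c(F)cccc3F)n2C)n(Cc2ccco2)c1=O` has not yet been measured. It differs from compound 3 in one place: methoxymethyl in place of vinyl on a saturated chain carbon bound to an aromatic nitrogen, a change that, cut one bond further out, reads allyl to 2-methoxyethyl. Among the measured compounds shown here, no pair of measured compounds differs at this position, so the three values offer no step from which the size of this change can be read. With nothing in the data pointing either way, the number for compound 4 is expected to stay close to that of compound 3, with the step of a 1.1-fold higher number from compound 3 to compound 4 (0.06 log units; within the scatter) expected to fall within the scatter. The estimate for compound 4 in this assay is 150 nM, with a range from 55 nM to 420 nM.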

Compound 4, inhibition constant: 195 nM
Estimate against measurement, compound 4: 1.3-fold (0.11 log units) below; the range from low to high includes it.
By their numbers in this assay, from the lowest: compounds 1, 2, 3 and 4 (each within the scatter of the next).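

With this pair, the position gives its first readable step: in this assay, allyl to 2-methoxyethyl on a saturated chain carbon bound to an aromatic nitrogen gives a 1.5-fold higher number from compound 3 to compound 4 (0.17 log units; within the scatter). A double bond outside aromatic rings leaves here and a hydrogen-bond acceptor enters, and on the shared core of this pair the number stays within the scatter, so this one change gives no detectable effect in this assay. The data offer no measured information that would explain this result.

A single step cannot show whether the same change would read alike with the other groups carried by compound 1 and compound 2. Nor do the compounds shown tell whether an amine, a carboxylic acid or a longer chain in place of the 2-methoxyethyl would move the number beyond the scatter.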